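One Ring Swap, Measured Twice on the Same Cells

The source may report more compounds than this note shows. Statements on the series, on what has been measured and on what is new or still open speak of the compounds shown alone.

Three compounds have been measured in a functional assay on MCF7 cells (Homo sapiens) for antiproliferative activity, read by sulforhodamine B assay, with a stated time of 48 h; on this read-out lower numbers stand for stronger inhibition and higher numbers for weaker inhibition:
compound 1 `COc1cc(C(=O)/C=C/c2ccccc2-c2ccc(F)cc2)ccc1O` gives 5400 nM
compound 2 `COc1cc(C(=O)/C=C/c2ccccc2-c2ccc(F)nc2)ccc1O` gives 27000 nM
compound 3 `COc1ccc(C(=O)/C=C/c2ccccc2-c2ccc(F)cc2)cc1O` gives 560 nM

Compound 1 and compound 2 share a core and differ in one place: 6-fluoropyridin-3-yl in place of 4-fluorophenyl on an aromatic carbon. This change produced a 5.0-fold higher number from compound 1 to compound 2 (0.70 log units; beyond the scatter), so the number rose and the inhibition weakened.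

Compound 3 has the same atoms as compound 1 joined differently; how the two cores differ is not broken down here. Among the three measured compounds, compound 3 has the lowest number, and its steps to compound 1 and compound 2 both lie beyond the usual scatter, so on this read-out it is the strongest inhibitor of the three.

Compound 4 `COc1ccc(C(=O)/C=C/c2ccccc2-c2ccc(F)nc2)cc1O` has not yet been measured. It stands to compound 3 as compound 2 stands to compound 1: 6-fluoropyridin-3-yl in place of 4-fluorophenyl on an aromatic carbon. The place of the change is described in the same words in both pairs, so this is the same change made on a different core.

The expectation for compound 4 rests on a single precedent, the step from compound 1 to compound 2, a 5.0-fold higher number from compound 1 to compound 2 (0.70 log units; beyond the scatter), applied to the value of compound 3, 560 nM. Whether a change transfers unchanged from one core to another is not known from these data, so the range is kept wide. The estimated step is a 5.0-fold higher number from compound 3 to compound 4 (0.70 log units; beyond the scatter). Compound 4 is therefore expected to give about 2800 nM in this assay, most likely between 900 nM and 9000 nM.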

Compound 4, half-maximal inhibitory concentration: 2000 nM
Compound 4: the middle estimate sits 1.4-fold (0.15 log units) above what was measured; the measured number falls inside the stated range.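

On the core of compound 3, putting 6-fluoropyridin-3-yl in place of 4-fluorophenyl in this assay gave a 3.6-fold higher number from compound 3 to compound 4 (0.55 log units; beyond the scatter), so the number rose and the inhibition weakened, just as it did on the core of compound 1. The two steps therefore agree as closely as measurements of this kind can show: the same change on two cores in this assay, a 5.0-fold higher number (0.70 log units; beyond the scatter) from compound 1 to compound 2 and a 3.6-fold higher number (0.55 log units; beyond the scatter) from compound 3 to compound 4, 1.4-fold (0.15 log units) apart, within the scatter of two such steps This means that, for these two cores, the change carried across in both direction and size, and a step measured on one core served as a fair guide to the other, but two cores in one assay on one cell line cannot establish a general rule for the series, and nothing here explains why the swap weakens inhibition.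

The compounds shown explore only one replacement for the 4-fluorophenyl group, so it remains open how the number would respond if the fluorine on that ring were replaced by an amine, a carboxylic acid or a methoxy group. On these data alone, it also remains open whether the same swap would give a similar step on a third core or on cells other than MCF7.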